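Bromo to tert-butyl on a core that shows no cytotoxicity

The source may report more compounds than this note shows. Statements on the series, on what has been measured and on what is new or still open speak of the compounds shown alone.

Compound 1 `CCOC(=O)C12C(=O)OCC=C1COC2c1ccccc1` and compound 2 `CCOC(=O)C12C(=O)OCC=C1COC2c1ccc(Br)cc1` share one core and differ only at an aromatic carbon. In a functional assay on QGY cells (Homo sapiens) for cytotoxicity, read by MTT assay (a higher number here means a weaker inhibitor, a lower number a stronger inhibitor), compound 1 gives only a limit, > 1000000 nM. In this assay compound 2 likewise gives only a limit, > 1000000 nM. The step that the two limits leave unreadable from compound 1 to compound 2 therefore cannot be sized because of the limit of > 1000000 nM in this assay, at which 2 of the 2 values shown sit. Compound 3 `CCOC(=O)C12C(=O)OCC=C1COC2c1ccc(C(C)(C)C)cc1` is the next member, and its difference from compound 2 is tert-butyl in place of bromo on an aromatic carbon. No measured step between the compounds shown can be read, so nothing in the numbers bears on the size or direction of this change beyond the fact that the core itself has not yet produced a readable inhibition. Compound 3 is accordingly expected to sit at the same limit, with an estimate of 1000000 nM and a range from 300000 nM to 3000000 nM. The expected step is a number no higher from compound 2 to compound 3 (the limit leaves the size open), meaning no change beyond the scatter.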

Compound 3, half-maximal inhibitory concentration: > 1000000 nM
Compound 3: no number, only a limit; the forecaster's own chance of this, stated with the estimate: 85%; the middle value lies on the limit itself.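

In this assay compound 3 gives only a limit, as do compound 1 and compound 2, so no new step among these compounds can be read: the limit of > 1000000 nM in this assay, at which 3 of the 3 values shown sit.

Whether any other group on this aromatic carbon, or any other change to the shared core, gives a readable value in this assay is left open by the compounds shown.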